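A few compounds are considered here, and "the series" means these few. Any claim that something is new, unique, unknown or untested is made for them only; others in the source may bear on it.

Compound 1 `Cc1nc(-c2ccccc2)c(C(=O)N2CCN(c3cccc(C#N)c3)CC2)o1` is the stronger of the two compounds measured in a functional assay on HL-60 cells (Homo sapiens) for inhibition, read by MTT assay, with a stated time of 72 h (a higher number here means a weaker inhibitor, a lower number a stronger inhibitor), where compound 1 gives 39.6 nM. Compound 2 `CCc1nc(-c2ccc(F)cc2)c(C(=O)N2CCN(c3cccc(OC)c3)CC2)o1` gives 411 nM in this assay, a weaker result, though it differs from compound 1 in several places at once. Compound 3 `Cc1ccc(C)c(N2CCN(C(=O)c3oc(C)nc3-c3ccccc3)CC2)c1` carries a single change from compound 1: 2,5-dimethylphenyl in place of 3-cyanophenyl on an amine nitrogen in a ring. For the measured compounds named here, with no comparable step among the measured compounds, the expected step of a 2.5-fold higher number from compound 1 to compound 3 (0.40 log units; beyond the scatter) in this assay is a modest loss, toward a higher number, of a size only slightly beyond the scatter. Compound 3 is therefore estimated at 100 nM, within a range of 30 nM to 350 nM.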

Compound 3, half-maximal inhibitory concentration: 31.3 nM
The estimate for compound 3 lay 3.2-fold (0.50 log units) above the measured number; the measured number falls inside the stated range.
By their numbers in this assay, from the lowest: compounds 3 and 1 (each within the scatter of the next); then compound 2.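

In this assay the change on the amine nitrogen in the ring gives a 1.3-fold lower number from compound 1 to compound 3 (0.10 log units; within the scatter) and thus no readable shift, although the expected loss did not appear. The entering 2,5-dimethylphenyl has no nitrile and no hydrogen-bond acceptor, so on this core the nitrile of 3-cyanophenyl is not needed for a number of this size. Nothing at hand gives a reason for this result.

Going by these compounds, whether this position also accepts a phenyl ring bearing a carboxylic acid or an amine, or a plain alkyl chain in place of the aromatic ring, remains open. So does whether 2,5-dimethylphenyl behaves the same way on the core of compound 2.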